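A few compounds are considered here, and "the series" means these few. Any claim that something is new, unique, unknown or untested is made for them only; others in the source may bear on it.

Compound 1, `CCCc1nc(-c2ccccc2)c(CNCCN2CCN(c3cccc(C(F)(F)F)c3)CC2)o1`, stands lowest of the two compounds measured in an assay on HEK293 cells for inhibition of Voltage-dependent T-type calcium channel subunit alpha-1G (Homo sapiens), read by fluorescence, tested at 10 uM; on this read-out lower numbers stand for less inhibition and higher numbers for more inhibition at the one concentration tested (going by the name of the read-out): in this assay compound 1 gives 56.3%. Compound 2, `CCCc1nc(-c2ccccc2)c(CNCCN2CCN(C(c3ccccc3)c3ccccc3)CC2)o1`, gives 71.9% in this assay, a number higher than that of compound 1 by more than the usual scatter. Compound 3, `CCCc1nc(-c2ccccc2)c(CNCCN2CCN(c3cccc(C)c3C)CC2)o1`, has not been measured. It differs from compound 1 in one place: 2,3-dimethylphenyl in place of 3-(trifluoromethyl)phenyl on an amine nitrogen in a ring. Among the compounds with values here, no pair of measured compounds shows this change, so its effect cannot be read from the numbers at hand. On these data alone, compound 2 shows that a change at this ring nitrogen can move the read-out, but the direction for compound 3 remains open. The account expects a number 6.3 percentage points lower from compound 1 to compound 3 (within the scatter), a small step that stays within the scatter, if anything slightly downward. Compound 3 is therefore estimated at 50%, with a range from 30% to 70%.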

Compound 3, a percentage reported as inhibition, at one concentration (the size of the read-out at that concentration, not a potency): 66.7%
For compound 3 the middle estimate is 16.7 percentage points below the measured one; the range from low to high includes it.
By their numbers in this assay, from the lowest: compound 1; then compounds 3 and 2 (each within the scatter of the next).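

In this assay, 2,3-dimethylphenyl in place of 3-(trifluoromethyl)phenyl on the amine nitrogen in the ring gives a number 10.4 percentage points higher from compound 1 to compound 3 (beyond the scatter) as the first step at this position that can be read from a listed pair. It shows that the read-out responds to the substituents on this phenyl ring, even with the phenyl ring itself kept and all else in the core of compound 1 unchanged, although the step is only modest. No measurement at hand accounts for the rise.

The compounds shown leave open whether both methyl groups are needed for this step or whether one alone would give it. They also do not show how a chlorine, a methoxy group or a pyridine ring in place of this phenyl ring would read.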